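This account rests on a few compounds, and the source may have more. Where it says the series, first, only, none or still open, it means among the compounds named here.

Measured so far:
- compound 1, `C=CCn1c(=O)/c(=C\c2cccc(F)c2)[nH]c(=O)/c1=C\c1ccccc1OC`: 8890 nM
- compound 2, `C=CCn1c(=O)/c(=C\c2ccccc2OC)[nH]c(=O)/c1=C\c1ccccc1OC`: 15700 nM

In a functional assay on HL-60 cells (Homo sapiens) for cytotoxicity, read by CCK-8 assay, with a stated time of 72 h (on this read-out higher numbers stand for weaker inhibition and lower numbers for stronger inhibition), compound 2 gives the higher of the two numbers, with compound 1 close by, and the step of a 1.8-fold higher number from compound 1 to compound 2 (0.25 log units; within the scatter) lies within the scatter. Compound 3, `C=CCn1c(=O)/c(=C\c2ccccc2C(F)(F)F)[nH]c(=O)/c1=C\c1ccccc1OC`, differs from compound 2 by trifluoromethyl in place of methoxy on an aromatic carbon. Among the measured compounds shown here, no measured step swaps a methoxy for a trifluoromethyl, so the only guide is that the single measured change on this compound barely moved the read-out. On that basis, no step beyond the scatter is expected for the step of a 1.1-fold lower number from compound 2 to compound 3 (0.05 log units; within the scatter). Compound 3 is therefore estimated at 14000 nM, with a range from 5000 nM to 40000 nM.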

Compound 3, half-maximal inhibitory concentration: 4600 nM
Beside the measured number, compound 3's estimate is 3.0-fold (0.48 log units) above it, outside the stated range (below it).
By their numbers in this assay, from the lowest: compounds 3, 1 and 2 (each within the scatter of the next, the first and the last beyond it).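

Among the compounds shown here, at this place on the aromatic ring, trifluoromethyl in place of methoxy gives the first step beyond the scatter in this assay: a 3.4-fold lower number from compound 2 to compound 3 (0.53 log units; beyond the scatter). The other comparison, a 1.9-fold lower number from compound 1 to compound 3 (0.29 log units; within the scatter), stays within the scatter, so 2-(trifluoromethyl)phenyl and 3-fluorophenyl cannot be ranked against each other here. No measurement available here explains the step from methoxy to trifluoromethyl. The compounds shown leave open whether the lower number comes from gaining trifluoromethyl or from losing methoxy. They also leave open what a chlorine atom, a nitrile or an amine would give at this place.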